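From cyclohexyl to cyclobutyl on the shared core

A few compounds are considered here, and "the series" means these few. Any claim that something is new, unique, unknown or untested is made for them only; others in the source may bear on it.

Among the compounds with values here, in an ADME assay on microsomes from liver (Homo sapiens) for metabolic stability, read by LC-MS, using NADPH, with a stated time of 10 min, tested at 10 uM (a lower number here means that the compound disappears faster, a higher number that the compound lasts longer), compound 3 `Nc1ncnc2c1c(Oc1cc(C(F)(F)F)ccn1)nn2C1CCCCC1` gives 0.55 h, the only actual number so far. Compound 1 `Nc1ncnc2c1c(Oc1cc(C(F)(F)F)ccn1)nn2[C@H]1CC[C@H](CO)CC1` gives > 2.41 h, which is a limit of the assay. Compound 2 `Nc1ncnc2c1c(Oc1cc(C(F)(F)F)ccn1)nn2C1CCC(O)C1` gives > 2.41 h, also a limit.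

Compound 4 `Nc1ncnc2c1c(Oc1cc(C(F)(F)F)ccn1)nn2C1CCC1` has cyclobutyl in place of cyclohexyl on an aromatic nitrogen.

Within the data shown here, no measured step makes this exact change. The closest evidence is an at least 4.3-fold lower number from compound 1 to compound 3 (0.64 log units; beyond the scatter) and an at least 4.3-fold lower number from compound 2 to compound 3 (0.64 log units; beyond the scatter), but both also involve loss of a hydroxyl-bearing group, which compound 4 does not gain. a step that the two limits leave unreadable from compound 1 to compound 2 does change the ring on the nitrogen, but gives no readable size. The expectation from this assay is therefore tentative, and smaller than those two steps. The expected change is a 1.8-fold higher number from compound 3 to compound 4 (0.26 log units; within the scatter), a small upward step. The estimated half-life of compound 4 is 1 h, with an expected range of 0.45 h to 2.4 h.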

Compound 4, half-life: 1.02 h
Compound 4: middle estimate off by 1.0-fold (0.01 log units), on the low side, and the stated range covers the measured number.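

In this assay, changing only the ring on the aromatic nitrogen gives a 1.9-fold higher number from compound 3 to compound 4 (0.27 log units; within the scatter), so this position shows no readable difference between cyclobutyl and cyclohexyl. Compound 4 remains apart from the two compounds that carry a hydroxyl-bearing group, with an at least 2.3-fold lower number from compound 2 to compound 4 (0.37 log units; beyond the scatter) and an at least 2.3-fold lower number from compound 1 to compound 4 (0.37 log units; beyond the scatter) as the steps. Across these four compounds, the longer half-lives go with 4-(hydroxymethyl)cyclohexyl and 3-hydroxycyclopentyl rather than with ring size, and no compound shown goes against this.

Going by these compounds, compound 1 and compound 2 both stand at a limit rather than a number, so the full size of those two steps stays open: the limit of > 2.41 h in this assay, at which 2 of the 4 values shown sit. Also open, on these data alone, is how cyclobutyl would behave with a hydroxyl, an amine or a carboxylic acid on its ring.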